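From 3-chlorophenyl to 4-bromophenyl on the carbonyl carbon

A few compounds are considered here, and "the series" means these few. Any claim that something is new, unique, unknown or untested is made for them only; others in the source may bear on it.

In a functional assay on HepG2 cells (Homo sapiens) for antiproliferative activity, read by MTT assay, with a stated time of 48 h (a higher number here means a weaker inhibitor, a lower number a stronger inhibitor), compound 1 `COc1ccc(/C=C/c2cc(OC)cc(OC)c2/C=C/C(=O)c2cccc(OC)c2)cc1` gives 11.6 ug/mL and compound 2 `COc1ccc(/C=C/c2cc(OC)cc(OC)c2/C=C/C(=O)c2cccc(Cl)c2)cc1` gives 9.5 ug/mL. Compound 2 therefore stands level with compound 1, and the series offers no other number to place it against. The next compound, compound 3 `COc1ccc(/C=C/c2cc(OC)cc(OC)c2/C=C/C(=O)c2ccc(Br)cc2)cc1`, keeps the shared core and differs in one group: 4-bromophenyl in place of 3-chlorophenyl on a carbonyl carbon. In words, 4-bromophenyl stands in place of 3-chlorophenyl on a carbonyl carbon. Going by the values given here, the only measured step that bears on this is a 1.2-fold lower number from compound 1 to compound 2 (0.09 log units; within the scatter), for chloro in place of methoxy on an aromatic carbon. Among the compounds with values here, no measured compound carries 4-bromophenyl, so this evidence is indirect. On that small step, no change beyond the scatter is expected in this assay. The expected step is a 1.1-fold higher number from compound 2 to compound 3 (0.02 log units; within the scatter). Compound 3 is estimated at 10 ug/mL, with an expected range of 4.5 ug/mL to 22 ug/mL.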

Compound 3, half-maximal inhibitory concentration: 12.9 ug/mL
For compound 3 the middle estimate is 1.3-fold (0.11 log units) below the measured one, and the stated range covers the measured number.
By their numbers in this assay, from the lowest: compounds 2, 1 and 3 (each within the scatter of the next).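

Replacing 3-chlorophenyl with 4-bromophenyl on the carbonyl carbon stays within the scatter in this assay (a 1.4-fold higher number from compound 2 to compound 3 (0.13 log units; within the scatter)). The comparison with the methoxy member also stays within the scatter (a 1.1-fold higher number from compound 1 to compound 3 (0.05 log units; within the scatter)), so 3-methoxyphenyl, 3-chlorophenyl and 4-bromophenyl cannot be told apart at this position in this series. No measurement is available to account for this lack of separation.

As far as these compounds go, whether this position accepts anything beyond these substituted phenyl groups stays open: an amine or a carboxylic acid on the ring, or a longer chain in place of the aryl group, could behave differently. The identity of the halogen also remains unseparated from where it sits, with chloro and bromo present only as 3-chlorophenyl and 4-bromophenyl.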